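This account rests on a few compounds, and the source may have more. Where it says the series, first, only, none or still open, it means among the compounds named here.

Measured: compound 1 `c1ccc(COc2ccccc2Nc2ncnc3cc4c(cc23)OCCOCCOCCO4)cc1`; compound 2 `FC(F)(F)c1ccc(COc2ccccc2Nc2ncnc3cc4c(cc23)OCCOCCOCCO4)cc1`.

In a functional assay on MCF7 cells (Homo sapiens) for antiproliferative activity, read by MTT assay, with a stated time of 72 h (a higher number here means a weaker inhibitor, a lower number a stronger inhibitor), compound 1 gives 63300 nM. Compound 2 gives only a limit of the assay, > 100000 nM, so it stands at the edge of the measured range, see (the limit of > 100000 nM in this assay, at which 1 of the 2 values shown sits). For the measured compounds named here, the single step seen, an at least 1.5-fold higher number from compound 1 to compound 2 (0.19 log units; that floor lies within the scatter), runs from compound 1 to compound 2 and bears only loosely on the next change. Compound 3 `O=[N+]([O-])c1ccc(COc2ccccc2Nc2ncnc3cc4c(cc23)OCCOCCOCCO4)cc1` differs from compound 2 by nitro in place of trifluoromethyl on an aromatic carbon. Going by the values given here, no measured step covers this exchange, so no change beyond the scatter is expected and compound 3 is expected to remain near the limit, an expected step of a number no higher from compound 2 to compound 3 (the limit leaves the size open). Compound 3 is thus estimated at 100000 nM, with a range from 35000 nM to 300000 nM.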

Compound 3, half-maximal inhibitory concentration: > 100000 nM
Compound 3: no number, only a limit; the forecaster's own chance of this, stated with the estimate: 60%; the middle value sits exactly at the limit.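

In this assay, nitro on this aromatic carbon, para to a large group, gives an at least 1.5-fold higher number from compound 1 to compound 3 (0.19 log units; that floor lies within the scatter). The result for compound 3 is a limit, so a second, different substituent at this position joins trifluoromethyl without a number inside the measured range: (the limit of > 100000 nM in this assay, at which 2 of the 3 values shown sit). The step between compound 2 and compound 3 cannot be read.

Open, going by these compounds, is how far compound 2 and compound 3 lie past the limit. Also open, on these data alone, is whether an amine or a carboxylic acid on this carbon would give a readable value.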